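A few compounds are considered here, and "the series" means these few. Any claim that something is new, unique, unknown or untested is made for them only; others in the source may bear on it.

Compound 1 `CCOC(=O)c1cnc(-c2ccccc2)s1` stands at the limit of an assay on HEK293 cells for inhibition of transient receptor potential cation channel subfamily M member 8 (Homo sapiens), read by FLIPR, with stated times of 5 min and 3 min (on this read-out lower numbers stand for stronger inhibition and higher numbers for weaker inhibition), rather than at a measured number, with a value of > 100000 nM. It is the only one of the three measured compounds to sit at that limit (the limit of > 100000 nM in this assay, at which 1 of the 3 values shown sits). The other two measured compounds each carry a hydroxy on the shared core: compound 2 `CON(C)C(=O)c1sc(-c2ccccc2O)nc1O` gives 66 nM in this assay, and compound 3 `CCn1nnc(-c2sc(-c3ccc(F)cc3)nc2O)n1` gives 286 nM in this assay.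

Compound 4 `CCOC(=O)c1sc(-c2ccccc2)nc1O` is not yet measured. It differs from compound 1 by a single change (hydroxy in place of hydrogen on an aromatic carbon). For the measured compounds named here, no measured pair shows this exact step, so its size can only be expected. Because compound 2 reaches 66 nM and compound 3 reaches 286 nM while carrying the hydroxy on the core, the account expects the step to run toward stronger inhibition and to be large, well beyond the scatter, with the step from compound 1 to compound 4 estimated at an at least 250-fold lower number from compound 1 to compound 4 (2.39 log units; beyond the scatter). Compound 4 is therefore estimated to give 400 nM in this assay, with an expected range from 60 nM to 3000 nM.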

Compound 4, half-maximal inhibitory concentration: 32 nM
The estimate for compound 4 lay 13-fold (1.10 log units) above the measured number; measured number outside the range, below it.
By their numbers in this assay, from the lowest: compound 4; then compound 2; then compound 3. At a limit, above all of these: compound 1.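

In this assay, hydroxy in place of hydrogen on the aromatic carbon next to the ring nitrogen gives an at least 3100-fold lower number from compound 1 to compound 4 (3.49 log units; beyond the scatter), a large step beyond the scatter. Compounds 2 and 3 carry the same hydroxy but differ from compound 1 in other places too, whereas this pair differs in that one place alone and ties the step to this position. The step is a minimum, as compound 1 stands at a limit of the assay rather than at a number: the limit of > 100000 nM in this assay, at which 1 of the 4 values shown sits.

The compounds shown leave open how an amine, a methoxy group or a fluorine would compare with the hydroxy on this carbon. They also leave open whether the step would keep its size with a carboxylic acid or a longer chain in place of the ethoxycarbonyl group.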